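Sulfonamide nitrogen substituents and antiproliferative activity

The compounds below may be only part of what the source reports. "The series", "measured", "known", "first", "only" and "open" are said of these compounds alone.

Compound 1 `CC(=O)NS(=O)(=O)c1ccc(N/C(S)=N\c2ccnc3cc(C(F)(F)F)ccc23)cc1` gives 37600 nM in a functional assay on AS49-RAW cells (Homo sapiens) for antiproliferative activity, read by sulforhodamine B assay, with a stated time of 48 h; on this read-out lower numbers stand for stronger inhibition and higher numbers for weaker inhibition. Compound 2 `Cc1cc(NS(=O)(=O)c2ccc(N/C(S)=N\c3ccnc4cc(C(F)(F)F)ccc34)cc2)on1` gives 60200 nM and compound 3 `O=S(=O)(Nc1ccccn1)c1ccc(N/C(S)=N\c2ccnc3cc(C(F)(F)F)ccc23)cc1` gives 33500 nM, both within the scatter of compound 1: a 1.6-fold higher number from compound 1 to compound 2 (0.20 log units; within the scatter), a 1.1-fold lower number from compound 1 to compound 3 (0.05 log units; within the scatter), and between them a 1.8-fold lower number from compound 2 to compound 3 (0.25 log units; within the scatter). Compound 1 thus stands second highest of the three numbers, with nothing separating the three beyond repeat variation. Compound 4 `COc1cc(NS(=O)(=O)c2ccc(N/C(S)=N\c3ccnc4cc(C(F)(F)F)ccc34)cc2)nc(OC)n1` differs from compound 1 as follows: 2,6-dimethoxypyrimidin-4-yl in place of acetyl on a sulfonamide nitrogen. The steps bearing on it are the two exchanges of acetyl for a ring on the same nitrogen, neither beyond the scatter. A step no larger than the scatter in this assay is therefore expected, in no particular direction, a 1.1-fold higher number from compound 1 to compound 4 (0.03 log units; within the scatter). Compound 4 is estimated at 40000 nM, within 18000 nM to 90000 nM.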

Compound 4, half-maximal inhibitory concentration: 64500 nM
Compound 4: middle estimate off by 1.6-fold (0.21 log units), on the low side; low and high end bracket the measured number.
By their numbers in this assay, from the lowest: compounds 3, 1, 2 and 4 (each within the scatter of the next).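

In this assay the 2,6-dimethoxypyrimidin-4-yl group on the sulfonamide nitrogen stays within the scatter of all three earlier substituents: a 1.7-fold higher number from compound 1 to compound 4 (0.23 log units; within the scatter), a 1.9-fold higher number from compound 3 to compound 4 (0.28 log units; within the scatter) and a 1.1-fold higher number from compound 2 to compound 4 (0.03 log units; within the scatter). Even the exchange of acetyl, with 3 heavy atoms, for this ring, with 10 heavy atoms, therefore brings no step beyond the scatter. Nothing measured here gives a reason for these numbers. Still open, on these data alone, is how a longer alkyl chain, an amine or a carboxylic acid on this nitrogen would read. Also open, as far as these compounds go, is whether any substituent here moves the number beyond the scatter.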